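Cyclopropane aryl swaps on the biphenyl amide series

A few compounds are considered here, and "the series" means these few. Any claim that something is new, unique, unknown or untested is made for them only; others in the source may bear on it.

Three analogues of the shared core have been measured in a functional assay for agonist activity at G protein-coupled receptor 88 (Homo sapiens), read by HTRF and cAMP accumulation; a lower number here means that less compound is needed, a higher number that more compound is needed for the effect. Compound 1, `CC[C@H](C)[C@H](N)CN(C(=O)[C@@H]1C[C@H]1c1cccc(OC)c1)c1ccc(-c2ccccc2)cc1`, gives 3000 nM. Compound 2, `CC[C@H](C)[C@H](N)CN(C(=O)[C@@H]1C[C@H]1c1cc(F)ccc1F)c1ccc(-c2ccccc2)cc1`, gives 770 nM. Compound 3, `CC[C@H](C)[C@H](N)CN(C(=O)[C@@H]1C[C@H]1c1c(F)cccc1F)c1ccc(-c2ccccc2)cc1`, gives 11000 nM, the highest number of the three: its nearest neighbour is compound 1 and its furthest compound 2.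

All three steps known so far change the aryl group on the saturated ring carbon. The change was a 3.9-fold lower number from compound 1 to compound 2 (0.59 log units; beyond the scatter), then a 3.7-fold higher number from compound 1 to compound 3 (0.56 log units; beyond the scatter), and between the two difluoro isomers a 14-fold higher number from compound 2 to compound 3 (1.15 log units; beyond the scatter). Each step is beyond the scatter, so this position clearly moves the number, and the size of the move depends on which aryl group is present.

Compound 4, `CC[C@H](C)[C@H](N)CN(C(=O)[C@@H]1C[C@H]1c1nccs1)c1ccc(-c2ccccc2)cc1`, carries 1,3-thiazol-2-yl in place of 2,6-difluorophenyl on a saturated ring carbon. Among the measured compounds shown here, no measured step replaces the six-membered carbon ring with a five-membered ring holding two hetero atoms, so there is no direct precedent. Because compound 3 sits at 11000 nM and the other aryl groups gave lower numbers, the working expectation is a modest step toward the middle of the series, a 3.1-fold lower number from compound 3 to compound 4 (0.50 log units; beyond the scatter), with wide uncertainty. Compound 4 is therefore estimated at 3500 nM, within a range from 900 nM to 14000 nM.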

Compound 4, half-maximal effective concentration: 210 nM
The estimate for compound 4 lay 17-fold (1.22 log units) above the measured number; the whole stated range lies above it.
By their numbers in this assay, from the lowest: compound 4; then compound 2; then compound 1; then compound 3.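

Until now the lowest number at this position belonged to a difluorophenyl group, but 1,3-thiazol-2-yl goes lower still, with a 3.7-fold lower number from compound 2 to compound 4 (0.56 log units; beyond the scatter) in this assay, so among these analogues the lowest number does not need a six-membered aromatic ring of carbon only. The same group also stands well clear of the other two aryl groups, with a 14-fold lower number from compound 1 to compound 4 (1.15 log units; beyond the scatter) and a 52-fold lower number from compound 3 to compound 4 (1.72 log units; beyond the scatter), the latter the widest step yet seen at this position and wider than the gap between the two difluoro isomers. The entering group has 5 heavy atoms against 8 and 2 hydrogen-bond acceptors against 0, but no measurement at hand connects the lower number with either count or with anything else about this change.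

Still open, as far as these compounds go, is whether the low number is specific to 1,3-thiazol-2-yl or would extend to another heteroaryl group on this carbon, such as 1,3-oxazol-2-yl or pyridin-2-yl. Also open, from the compounds shown here alone, is how the number would respond to a methyl group on the thiazole ring itself.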